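This account rests on a few compounds, and the source may have more. Where it says the series, first, only, none or still open, it means among the compounds named here.

Measured so far in a functional assay on A549 cells (Homo sapiens) for cytotoxicity, read by sulforhodamine B assay; on this read-out lower numbers stand for stronger inhibition and higher numbers for weaker inhibition:
compound 1 `Cn1c2c(c3ccccc3c1=O)CCOc1ccccc1-2` gives 66800 nM
compound 2 `Cc1ccc2c3c(n(C)c(=O)c2c1)-c1ccccc1OCC3` gives 30300 nM
compound 3 `COc1ccc(Cn2c3c(c4ccccc4c2=O)CCOc2ccccc2-3)cc1` gives 11000 nM

Compound 2 differs from compound 1 by methyl in place of hydrogen on an aromatic carbon; this step is a 2.2-fold lower number from compound 1 to compound 2 (0.34 log units; beyond the scatter). Compound 3 differs from compound 1 by 4-methoxyphenyl in place of hydrogen on a saturated chain carbon bound to an aromatic nitrogen; this step is a 6.1-fold lower number from compound 1 to compound 3 (0.78 log units; beyond the scatter). Compound 3 therefore gives the lowest number of the three, with compound 2 nearest and compound 1 furthest.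

Compound 4 `COc1ccc(Cn2c3c(c4cc(C)ccc4c2=O)CCOc2ccccc2-3)cc1` has not yet been measured. It differs from compound 3 by methyl in place of hydrogen on an aromatic carbon. This is the same change as from compound 1 to compound 2, made once so far among the compounds shown, and now made on the core of compound 3 instead of the core of compound 1. The expectation for compound 4 rests on that single earlier instance and on the value of compound 3, 11000 nM. In this assay the expected step is a 2.0-fold lower number from compound 3 to compound 4 (0.30 log units; within the scatter), to be set beside the measured 2.2-fold lower number from compound 1 to compound 2 (0.34 log units; beyond the scatter). Compound 4 is expected to give about 5500 nM in this assay, with the estimate spanning 2500 nM to 12000 nM.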

Compound 4, half-maximal inhibitory concentration: > 100000 nM
Compound 4: no number, only a limit; the forecaster's own chance of this, stated with the estimate: 2%; middle value at least 18-fold (1.25 log units) away from the limit.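

In this assay compound 4 reaches only a limit, > 100000 nM, and this is not a number: the limit of > 100000 nM in this assay, at which 1 of the 4 values shown sits. Methyl in place of hydrogen on an aromatic carbon gives an at least 9.0-fold higher number from compound 3 to compound 4 (0.95 log units; beyond the scatter), so the change does not carry over between the two cores in direction or in size: the same change on two cores in this assay, a 2.2-fold lower number (0.34 log units; beyond the scatter) from compound 1 to compound 2 and an at least 9.0-fold higher number (0.95 log units; beyond the scatter) from compound 3 to compound 4, at least 20-fold (1.30 log units) apart, beyond the scatter of two such steps. This shows that the step measured on one core could not be transferred to the other core in this pair, but it does not give the true size of the new step or set a rule for any other core.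

On these data alone, it remains open whether the opposite direction is tied to methyl itself or to its combination with the 4-methoxyphenyl group on the saturated chain carbon. As far as these compounds go, it is also open whether a chlorine atom or an amine on the same aromatic carbon would follow the lower number seen with compound 2 or reach a limit as compound 4 does.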